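The source may hold more compounds than are shown below. What is called first, only, known or untested is meant among the compounds shown, and "the series" means these compounds.

Two compounds have numbers in an ADME assay (liver) for metabolic stability, with Liver microsome (Homo sapiens) as the target, read by LC-MS, using microsomes, with a stated time of 60 min, tested at 1 uM; on this read-out lower numbers stand for slow clearance and higher numbers for fast clearance. Compound 1 `Cc1cc(Br)ccc1C(=O)Nc1ccccn1` gives 97 uL/min, while compound 2 `Cc1ccccc1C(=O)Nc1ccc(F)cn1` gives 43 uL/min, the lowest of the two, with compound 1 standing a gap beyond the scatter above it. Compound 3 `COc1ccc(NC(=O)c2ccccc2C)nc1` has not yet been measured in this assay; it differs from compound 2 by methoxy in place of fluoro on an aromatic carbon, the incoming methoxy sitting two atoms from the ring nitrogen. The expected step is a 1.7-fold higher number from compound 2 to compound 3 (0.24 log units; within the scatter), a modest rise that may barely clear the scatter. Compound 3 is therefore estimated at 75 uL/min, with a range from 35 uL/min to 160 uL/min.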

Compound 3, intrinsic clearance in a liver preparation (reported as CLH), per the amount of preparation that the assay uses in the Liver microsome assay: 23 uL/min
Compound 3: the middle estimate sits 3.3-fold (0.51 log units) above what was measured; measured number outside the range, below it.
By their numbers in the Liver microsome assay, from the lowest: compounds 3 and 2 (each within the scatter of the next); then compound 1.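

In the Liver microsome assay, methoxy in place of fluoro on an aromatic carbon, two atoms from the ring nitrogen, gives a 1.9-fold lower number from compound 2 to compound 3 (0.27 log units; within the scatter), so this change does not separate the two compounds at this position. In a physicochemical assay for solubility, read by nephelometry, measured as kinetic solubility, at pH 6.5, tested at 10 mg/mL (a lower number here means a less soluble compound, a higher number a more soluble compound), compound 2 gives 25 ug/mL and compound 3 gives 12.5 ug/mL, a pair that also lies within the scatter. Nothing offered here accounts for either result.

As far as these compounds go, whether an amine or an ethoxy group at this same position would separate from compound 2 in the Liver microsome assay remains open. Compound 1 differs from both in more than one place, so it cannot show whether the methoxy result holds on another core.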